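The source may report more compounds than this note shows. Statements on the series, on what has been measured and on what is new or still open speak of the compounds shown alone.

Measured in an assay on CHO-TREX cells for antagonist activity at transient receptor potential cation channel subfamily A member 1 (Homo sapiens), read by FLIPR and calcium flux, with a stated time of 10 min; a lower number here means a stronger inhibitor, a higher number a weaker inhibitor:
compound 1 `Clc1ccccc1-c1ccc2[nH]ncc2c1`: 1230 nM
compound 2 `CCc1ccccc1-c1ccc2[nH]ncc2c1`: 584 nM
compound 3 `FC(F)(F)c1ccccc1-c1ccc2[nH]ncc2c1`: 164 nM

Compound 3 stands lowest of the three in this assay, with a 3.6-fold lower number from compound 2 to compound 3 (0.55 log units; beyond the scatter) and a 7.5-fold lower number from compound 1 to compound 3 (0.88 log units; beyond the scatter). Compound 4 `Fc1c(-c2ccccc2C(F)(F)F)ccc2[nH]ncc12` differs from compound 3 by fluoro in place of hydrogen on an aromatic carbon. For the measured compounds named here, every measured step changes the group on the pendant ring (a 2.1-fold lower number from compound 1 to compound 2 (0.32 log units; beyond the scatter), a 7.5-fold lower number from compound 1 to compound 3 (0.88 log units; beyond the scatter), a 3.6-fold lower number from compound 2 to compound 3 (0.55 log units; beyond the scatter)); none alters the core itself, so no step bears directly on this change. A single fluoro on the core is expected to shift the number only modestly, in no firm direction, and the working expectation is a step within the scatter. Compound 4 is therefore expected at 150 nM (range 50 nM to 450 nM), meaning an estimated 1.1-fold lower number from compound 3 to compound 4 (0.04 log units; within the scatter).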

Compound 4, half-maximal inhibitory concentration: 296 nM
Compound 4: middle estimate off by 2.0-fold (0.30 log units), on the low side, within the range that was stated.
By their numbers in this assay, from the lowest: compounds 3, 4 and 2 (each within the scatter of the next, the first and the last beyond it); then compound 1.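

The only change to the shared core among these compounds, fluoro in place of hydrogen on an aromatic carbon, gives a 1.8-fold higher number from compound 3 to compound 4 (0.26 log units; within the scatter), so this position, ortho to a large group, accepts fluoro without a step beyond the scatter. The steps on the pendant ring all lie beyond the scatter, whereas this one does not separate the two compounds. No measurement shown accounts for this result.

On these data alone, whether fluoro behaves the same with chloro or ethyl on the pendant ring remains open. So does the effect of a different group at this position, such as methoxy, an amine or a nitrile.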